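A Mirror Image of the More Potent Compound

This account rests on a few compounds, and the source may have more. Where it says the series, first, only, none or still open, it means among the compounds named here.

So far only compound 1 and compound 2 have been measured in a functional assay on HEK293 cells for agonist activity at Neuronal acetylcholine receptor; alpha4/beta2 (Homo sapiens), read by FLIPR; on this read-out lower numbers stand for an effect already at smaller amounts and higher numbers for an effect only at larger amounts of compound. Compound 1 `N#Cc1cncc(N2C[C@@H]3CCNC[C@@H]32)c1` gives 2190 nM. Among the measured compounds shown here, compound 2 `c1ncc(N2CC[C@H]3CN[C@H]3C2)cn1` gives 350 nM, the lowest of the two numbers, with compound 1 the only neighbour and clearly separated from it. Compound 3 `c1ncc(N2CC[C@@H]3CN[C@@H]3C2)cn1` is not yet measured and differs from compound 2 in this way: the two compounds have the same atoms and bonds and differ only in configuration as drawn: 2 of 2 stereo elements differ (all stereocentres are inverted: mirror images); a stereocentre at a saturated ring carbon is drawn S in compound 2 and R in compound 3; a stereocentre at a saturated ring carbon is drawn R in compound 2 and S in compound 3. Nothing measured here shows how such a mirror pair compares, so the direction rests on expectation alone; a move to a higher number is anticipated. The expected step is a 5.7-fold higher number from compound 2 to compound 3 (0.76 log units; beyond the scatter). Compound 3 is therefore estimated at 2000 nM, within a range from 300 nM to 15000 nM.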

Compound 3, half-maximal effective concentration: 4390 nM
Compound 3: middle estimate off by 2.2-fold (0.34 log units), on the low side; the measured number falls inside the stated range.
By their numbers in this assay, from the lowest: compound 2; then compounds 1 and 3 (each within the scatter of the next).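

Compounds 1 and 2 differ in more than one place, so they could not show what configuration alone does. The mirror pair shows it: in this assay the change gives a 13-fold higher number from compound 2 to compound 3 (1.10 log units; beyond the scatter), with nothing entering or leaving. The step can be traced to configuration because of one fact: the fact that compounds 2 and 3 differ only in the configuration as drawn.

From the compounds shown here alone, whether inverting only one of the two stereocentres would give a number closer to compound 2 or to compound 3 remains open. So does the effect of adding a fluorine atom or a methoxy group to compound 2.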